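Free hydroxy in place of methoxymethyl: expected effect

The compounds below may be only part of what the source reports. "The series", "measured", "known", "first", "only" and "open" are said of these compounds alone.

Compound 3 `CCCCC/C=C\C/C=C\CCCCCCCc1cc(=O)c2c(O)cc(OCOC)c(C)c2o1` stands at the highest number of the three measured compounds in a functional assay on MDA-MB-231 cells (Homo sapiens) for antiproliferative activity, read by MTT assay (a lower number here means a stronger inhibitor, a higher number a weaker inhibitor), where compound 3 gives 16100 nM. Compound 1 `CCCCCCCCCCCCCCCc1cc(=O)c2c(O)cc(O)c(C)c2o1` gives 6790 nM and compound 2 `CCCCC/C=C\C/C=C\CCCCCCCc1cc(=O)c2c(O)cc(O)cc2o1` gives 6790 nM; both of these numbers lie lower than that of compound 3 by more than the usual scatter, while compound 1 and compound 2 do not differ from each other beyond it. Compound 4 `CCCCC/C=C\C/C=C\CCCCCCCc1cc(=O)c2c(O)cc(O)c(C)c2o1` has not yet been measured. It differs from compound 3 in one place: hydrogen in place of methoxymethyl on an oxygen on an aromatic ring. Both measured compounds that carry the free hydroxy group at this position, compound 1 and compound 2, sit at the lower number, so the change is expected to bring compound 4 to their level. The step of a 2.5-fold lower number from compound 3 to compound 4 (0.39 log units; beyond the scatter) is expected to run toward lower numbers and to exceed the scatter. For compound 4 the estimate is 6500 nM, with a range of 3000 nM to 14000 nM, because compound 1 gives 6790 nM with the same free hydroxy group and methyl present.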

Compound 4, half-maximal inhibitory concentration: 6790 nM
The estimate for compound 4 lay 1.0-fold (0.02 log units) below the measured number; low and high end bracket the measured number.
By their numbers in this assay, from the lowest: compounds 1, 2 and 4 (each within the scatter of the next); then compound 3.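

Hydrogen in place of methoxymethyl on an oxygen on an aromatic ring gives, in this assay, a 2.4-fold lower number from compound 3 to compound 4 (0.37 log units; beyond the scatter), the first reading of this change between two compounds that differ in one place. With the free hydroxy group present, methyl in place of hydrogen on an aromatic carbon gives no change at the digits printed from compound 2 to compound 4 (within the scatter), and deca-1,4-dien-1-yl in place of octyl on a saturated chain carbon gives no change at the digits printed from compound 1 to compound 4 (within the scatter). Among these three steps, only the one at the oxygen lies beyond the scatter.

No measured information on the origin of this step is available. As far as these compounds go, it remains open whether a methyl or acetyl group on this oxygen would read like methoxymethyl or like hydrogen, and whether a much shorter chain, or an amine or carboxylic acid at the chain end, would shift the number.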